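Replacing the alkyne end group: expected clearance for compound 4

The source may report more compounds than this note shows. Statements on the series, on what has been measured and on what is new or still open speak of the compounds shown alone.

Measured compounds:
compound 1, `COc1cc(C(O)(C(F)(F)F)C(F)(F)F)cnc1N1CCN(S(=O)(=O)c2ccc(N)nc2)CC1`; in an ADME assay (liver) for metabolic stability, with Liver microsome (Rattus norvegicus) as the target, using microsomes and NADPH, with a stated time of 30 min, tested at 1 uM (a lower number here means slower removal, a higher number faster removal of the compound), compound 1 gives < 14 mL.min-1.g-1, which is a limit of the assay and not a number.
compound 2, `Nc1ccc(S(=O)(=O)N2CCN(c3ncc(C(O)(C(F)(F)F)C(F)(F)F)cc3C3CC3)CC2)cn1`; compound 2 gives 27 mL.min-1.g-1.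
compound 3, `Nc1ccc(S(=O)(=O)N2CCN(c3ncc(C(O)(C(F)(F)F)C(F)(F)F)cc3C#CC3CC3)CC2)cn1`; compound 3 gives 67 mL.min-1.g-1.

Compound 3 has the highest of the two numbers shown; its nearest neighbour is compound 2, with a 2.5-fold higher number from compound 2 to compound 3 (0.39 log units; beyond the scatter). Compound 4, `COCC#Cc1cc(C(O)(C(F)(F)F)C(F)(F)F)cnc1N1CCN(S(=O)(=O)c2ccc(N)nc2)CC1`, differs from compound 3 by methoxymethyl in place of cyclopropyl on a triple-bonded carbon. Going by the values given here, no measured step swaps these two groups, so the expectation rests on compound 3 itself. The steps of an at least 4.7-fold higher number from compound 1 to compound 3 (0.67 log units; beyond the scatter) and a 2.5-fold higher number from compound 2 to compound 3 (0.39 log units; beyond the scatter) changed the group on the aromatic carbon, not the end of the triple bond, and give no direction for this change. A step within the scatter, a 1.3-fold lower number from compound 3 to compound 4 (0.13 log units; within the scatter), is expected. For compound 4 the estimate is 50 mL.min-1.g-1, between 22 mL.min-1.g-1 and 110 mL.min-1.g-1.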

Compound 4, intrinsic clearance in microsomes: 399 mL.min-1.g-1
The estimate for compound 4 lay 8.0-fold (0.90 log units) below the measured number; the measured number lies above the stated range.
By their numbers in this assay, from the lowest: compound 2; then compound 3; then compound 4. At a limit, below all of these: compound 1.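

In this assay, going by these compounds alone, the end of the triple bond turns out to matter: a 6.0-fold higher number from compound 3 to compound 4 (0.77 log units; beyond the scatter), with methoxymethyl in place of cyclopropyl, while the earlier steps changed only the group on the aromatic carbon. The 3-methoxyprop-1-yn-1-yl group also stands well clear of cyclopropyl on the aromatic carbon, with a 15-fold higher number from compound 2 to compound 4 (1.17 log units; beyond the scatter). Compound 1 carries a limit of the assay and not a number, so an at least 28-fold higher number from compound 1 to compound 4 (1.45 log units; beyond the scatter) is only a floor: the limit of < 14 mL.min-1.g-1 in this assay, at which 1 of the 4 values shown sits.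

The compounds shown do not separate the effect of the oxygen from that of losing the ring. A plain propyl chain or a hydroxymethyl group at the end of the triple bond would begin to tell these apart.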